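Moving a hydroxy group in a growth inhibitor

A few compounds are considered here, and "the series" means these few. Any claim that something is new, unique, unknown or untested is made for them only; others in the source may bear on it.

In a functional assay on NCI-H522 cells (Homo sapiens) for inhibition, read by sulforhodamine B assay, with a stated time of 48 h (a higher number here means a weaker inhibitor of growth, a lower number a stronger inhibitor of growth), compound 1 `O=C(Cc1csc2nc(-c3ccc(Br)cc3)cn12)N/N=C/c1ccccc1` gives 14100 nM and compound 2 `O=C(Cc1csc2nc(-c3ccc(Br)cc3)cn12)N/N=C/c1ccccc1O` gives 5250 nM as the lower of the two numbers. Compound 3 `O=C(Cc1csc2nc(-c3ccc(Br)cc3)cn12)N/N=C/c1ccc(O)cc1` differs from compound 2 by 4-hydroxyphenyl in place of 2-hydroxyphenyl on a carbon with a double bond to nitrogen with 4-hydroxyphenyl in place of 2-hydroxyphenyl. Within the data shown here, the one measured step that bears on this is the modest 2.7-fold lower number from compound 1 to compound 2 (0.43 log units; beyond the scatter) on placing hydroxy in place of hydrogen, and it does not show what a different hydroxy position does. A step of similar or smaller size toward a higher number is therefore expected in this assay for this change. The expected change is a 1.4-fold higher number from compound 2 to compound 3 (0.15 log units; within the scatter) on this reasoning. For compound 3 the estimated value is 7500 nM within a range from 2800 nM to 17000 nM for now.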

Compound 3, concentration for 50% growth inhibition: 10700 nM
Compound 3: the middle estimate sits 1.4-fold (0.15 log units) below what was measured; low and high end bracket the measured number.
By their numbers in this assay, from the lowest: compound 2; then compounds 3 and 1 (each within the scatter of the next).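

In this assay, the place of the hydroxy group on the ring matters, if only modestly: 4-hydroxyphenyl in place of 2-hydroxyphenyl gives a 2.0-fold higher number from compound 2 to compound 3 (0.31 log units; beyond the scatter). Adding hydroxy in place of hydrogen at this other place gives a 1.3-fold lower number from compound 1 to compound 3 (0.12 log units; within the scatter), so of the two hydroxyphenyl groups only 2-hydroxyphenyl has a step beyond the scatter from the compound without hydroxy. Nothing available explains why the place of the group counts. As far as these compounds go, whether a methoxy group or an amine in place of that hydroxy would give a similar number remains open.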